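From Fluoro to Chloro in Compound 4

A few compounds are considered here, and "the series" means these few. Any claim that something is new, unique, unknown or untested is made for them only; others in the source may bear on it.

Measured in an ADME assay on the whole organism (Rattus norvegicus, strain Sprague-Dawley) for pharmacokinetics, using cassette dosing, at a dose of 0.5 mg/kg by the intravenous route; on this read-out higher numbers stand for fast clearance and lower numbers for slow clearance:
compound 1 `O=C(Nc1ccc2[nH]c(=O)oc2c1)C(=O)N1CCN(c2ccc(Cl)c(F)c2)CC1`: 5.6 mL/min/kg
compound 2 `C[C@@H]1CN(C(=O)C(=O)Nc2ccc3[nH]c(=O)oc3c2)CCN1c1ccc(Cl)cc1`: 15.6 mL/min/kg
compound 3 `C[C@@H]1CN(C(=O)C(=O)Nc2ccc3[nH]c(=O)oc3c2)CCN1c1ccc(F)c(F)c1`: 15.9 mL/min/kg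

Compound 3 stands level with compound 2 and above compound 1. Compound 4 `C[C@@H]1CN(C(=O)C(=O)Nc2ccc3[nH]c(=O)oc3c2)CCN1c1ccc(Cl)c(F)c1` follows from compound 3 by chloro in place of fluoro on an aromatic carbon. The closest measured evidence is a 1.0-fold higher number from compound 2 to compound 3 (0.01 log units; within the scatter), a swap between 4-chlorophenyl and 3,4-difluorophenyl that stayed within the scatter. Compound 1, at 5.6 mL/min/kg, carries the same 4-chloro-3-fluorophenyl group but differs elsewhere, which leaves some room on the low side. No step beyond the scatter is expected in this assay. The expected change is a 1.1-fold lower number from compound 3 to compound 4 (0.06 log units; within the scatter). For compound 4 the estimate is 14 mL/min/kg, with an expected range of 7.5 mL/min/kg to 25 mL/min/kg.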

Compound 4, clearance: 6 mL/min/kg
Estimate against measurement, compound 4: 2.3-fold (0.37 log units) above, outside the stated range (below it).
By their numbers in this assay, from the lowest: compounds 1 and 4 (each within the scatter of the next); then compounds 2 and 3 (each within the scatter of the next).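

In this assay this position proves sensitive: the earlier swap between 4-chlorophenyl and 3,4-difluorophenyl showed nothing, yet chloro for fluoro here gives a 2.7-fold lower number from compound 3 to compound 4 (0.42 log units; beyond the scatter), and fluoro for hydrogen gives a 2.6-fold lower number from compound 2 to compound 4 (0.41 log units; beyond the scatter). Only the 4-chloro-3-fluorophenyl group combines both halogens, and with it in place, the ring methyl gives just a 1.1-fold higher number from compound 1 to compound 4 (0.03 log units; within the scatter). No measurement shown accounts for this. From the compounds shown here alone, whether a bromo or a methoxy group on this aromatic carbon would keep the lower clearance stays open.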